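Compound 3 to compound 4: methylsulfonyl enters

The source may report more compounds than this note shows. Statements on the series, on what has been measured and on what is new or still open speak of the compounds shown alone.

Values in an ADME assay on microsomes from liver (Homo sapiens) for metabolic stability, read by LC-MS, using NADPH, with a stated time of 30 min, tested at 1 uM (on this read-out higher numbers stand for fast clearance and lower numbers for slow clearance), so far:
compound 1 `CC(C)c1noc(N2CCC(Oc3cc(N4CCc5cc(N6CC(O)CCC6=O)ccc54)ncn3)CC2)n1` gives 1 mL.min-1.g-1 in this series
compound 2 `CC(C)c1noc(N2CCC(Oc3cc(N4CCc5cc(N6CCCS6(=O)=O)ccc54)ncn3)CC2)n1` gives 18 mL.min-1.g-1 in this series
compound 3 `CC(C)c1noc(N2CCC(Oc3cc(N4CCc5cc(N6CCOCC6=O)ccc54)ncn3)CC2)n1` gives 27 mL.min-1.g-1 in this series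

Compound 3 sits with compound 2, well apart from compound 1. The step of a 1.5-fold higher number from compound 2 to compound 3 (0.18 log units; within the scatter) does not separate the upper pair, while the step of a 27-fold higher number from compound 1 to compound 3 (1.43 log units; beyond the scatter) sets compound 3 clearly apart from compound 1.

Compound 4 `CC(C)c1noc(N2CCC(Oc3cc(N4CCc5cc(S(C)(=O)=O)ccc54)ncn3)CC2)n1` differs from compound 3 in one place on the shared core. The change methylsulfonyl in place of 3-oxomorpholin-4-yl on an aromatic carbon puts methylsulfonyl in place of 3-oxomorpholin-4-yl on an aromatic carbon. Among the measured compounds shown here, no measured step brings in methylsulfonyl, so the guidance is indirect. The large steps of an 18-fold higher number from compound 1 to compound 2 (1.26 log units; beyond the scatter) and a 27-fold higher number from compound 1 to compound 3 (1.43 log units; beyond the scatter) both remove 5-hydroxy-2-oxopiperidin-1-yl, which compound 3 already lacks, so they set no size for this exchange. The nearer guide is the step of a 1.5-fold higher number from compound 2 to compound 3 (0.18 log units; within the scatter) in which one group lacking that hydroxy replaces another and the number remains within the scatter. No step beyond the scatter is therefore expected in this assay for this exchange, and no direction can be argued. The estimated step is a 1.2-fold lower number from compound 3 to compound 4 (0.09 log units; within the scatter) and remains only an expectation. For compound 4 the expected value is 22 mL.min-1.g-1 with an estimated range from 8 mL.min-1.g-1 to 50 mL.min-1.g-1 until the measurement is known.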

Compound 4, intrinsic clearance in microsomes: 69 mL.min-1.g-1
The estimate for compound 4 lay 3.1-fold (0.50 log units) below the measured number, outside the stated range (above it).
By their numbers in this assay, from the lowest: compound 1; then compounds 2 and 3 (each within the scatter of the next); then compound 4.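

Compounds 2 and 3 had suggested that, once the hydroxy-bearing group of compound 1 was gone, the choice of group at this aromatic carbon made little difference to this assay. Among the compounds shown here, compound 4 shows otherwise: methylsulfonyl, the only group here with no ring, gives a 2.6-fold higher number from compound 3 to compound 4 (0.41 log units; beyond the scatter) and a 3.8-fold higher number from compound 2 to compound 4 (0.58 log units; beyond the scatter), both modest but beyond the scatter, so the position still discriminates among groups lacking that hydroxy. For the compounds shown here, the distance from the low end of the series also grows, with a 69-fold higher number from compound 1 to compound 4 (1.84 log units; beyond the scatter), and 5-hydroxy-2-oxopiperidin-1-yl remains the one group here that gives a low number. No evidence is available that would explain this rise in clearance.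

The compounds shown do not separate the loss of a ring from the identity of the group, since compound 4 is the only member with no ring at this place and it also carries sulfur, as does compound 2. An open-chain acetylamino group, a primary amine or a carboxylic acid on the same aromatic carbon would be needed to test whether the number follows the sulfonyl group or the missing ring.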